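Extending the Amine Methyl to Ethyl on a Second Core

This account rests on a few compounds, and the source may have more. Where it says the series, first, only, none or still open, it means among the compounds named here.

Measured compounds:
compound 1, `CNCC(=O)Nc1cc(OC)ccc1C(=O)c1ccc(OC)c2c1C=CC(C)(C)O2`, 1590 nM in a functional assay on A2780 cells (Homo sapiens) for antiproliferative activity, read by MTT assay, with a stated time of 48 h; a lower number here means a stronger inhibitor, a higher number a weaker inhibitor
compound 2, `CCNCC(=O)Nc1cc(OC)ccc1C(=O)c1ccc(OC)c2c1C=CC(C)(C)O2`, 4090 nM in this assay
compound 3, `CNCC(=O)Nc1cc(OC)ccc1C(=O)c1cc(OC)c(OC)c(OC)c1`, 580 nM in this assay

Compound 1 and compound 2 share one core, while compound 3 carries another; the difference between the two cores is not broken down here. Within the first pair, the change methyl in place of hydrogen on a saturated chain carbon bound to an amine nitrogen gave a 2.6-fold higher number from compound 1 to compound 2 (0.41 log units; beyond the scatter). Among the three measured compounds, compound 3 has the lowest number, with compound 1 higher and compound 2 higher still.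

Compound 4, `CCNCC(=O)Nc1cc(OC)ccc1C(=O)c1cc(OC)c(OC)c(OC)c1`, has not yet been measured. It differs from compound 3 by methyl in place of hydrogen on a saturated chain carbon bound to an amine nitrogen, which is the same change at the same place as that between compound 1 and compound 2. Because that earlier change produced a 2.6-fold higher number from compound 1 to compound 2 (0.41 log units; beyond the scatter), compound 4 is expected to show a step of a 2.6-fold higher number from compound 3 to compound 4 (0.41 log units; beyond the scatter) in this assay, an expectation resting on a single precedent on a different core. Compound 4 is therefore estimated at 1500 nM, with a likely range from 700 nM to 3300 nM.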

Compound 4, half-maximal inhibitory concentration: 950 nM
Compound 4: the middle estimate sits 1.6-fold (0.20 log units) above what was measured; low and high end bracket the measured number.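

On the core of compound 3, in this assay, methyl in place of hydrogen on a saturated chain carbon bound to an amine nitrogen gave a 1.6-fold higher number from compound 3 to compound 4 (0.21 log units; within the scatter), so on this core the effect of the change cannot be told apart from the usual scatter. Set beside the step on the core of compound 1, the new step gives no sign that the outcome of this change depends on the core: the same change on two cores in this assay, a 2.6-fold higher number (0.41 log units; beyond the scatter) from compound 1 to compound 2 and a 1.6-fold higher number (0.21 log units; within the scatter) from compound 3 to compound 4, 1.6-fold (0.20 log units) apart, within the scatter of two such steps. That does not show that the two steps are equal, as only one of them lies beyond the scatter, and two pairs say nothing about how the change would behave on any further core.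

The compounds shown leave open whether a longer chain such as propyl, a branched group such as isopropyl, or a cyclic amine in the same place would follow the same course on both cores. They also leave open how a primary amine or a tertiary amine there would compare.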